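This account rests on a few compounds, and the source may have more. Where it says the series, first, only, none or still open, it means among the compounds named here.

Measured in a functional assay on HepG2 cells (Homo sapiens) for inhibition, read by MTT assay; a higher number here means a weaker inhibitor, a lower number a stronger inhibitor:
- Compound 1 `C[C@@H]1C(=O)O[C@H]2CC3=C[C@@H](C[C@@](C)(O)/C=C/[C@@H]21)OC3=O`: > 20000 nM, a limit
- Compound 2 `C=C1C(=O)O[C@H]2CC3=C[C@@H](C[C@@](C)(O)/C=C/[C@H]12)OC3=O`: > 20000 nM, a limit
- Compound 3 `C=C(C(=O)OC)[C@H]1/C=C/[C@](C)(O)C[C@@H]2C=C(C[C@@H]1OC(=O)/C(C)=C\C)C(=O)O2`: > 20000 nM, a limit

Compound 3 has no number, only a limit, and it shares that position with the other two compounds: the limit of > 20000 nM in this assay, at which 3 of the 3 values shown sit. Compound 4 `C=C(C)C(=O)O[C@H]1CC2=C[C@@H](C[C@@](C)(O)/C=C/[C@@H]1C(=C)C(=O)OC)OC2=O` carries 1-methylethenyl in place of 1-methylprop-1-en-1-yl on a carbonyl carbon. Within the data shown here, no step between measured compounds is available to guide the expectation, so no change beyond the scatter is expected in this assay, in either direction. The expected size of the step is a step that the limit leaves unreadable from compound 3 to compound 4. For compound 4 the estimated value is 25000 nM, within an expected range from 10000 nM to 50000 nM.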

Compound 4, half-maximal inhibitory concentration: > 20000 nM
Compound 4 gave a limit, no number; the forecaster's own chance of this, stated with the estimate: 80%; the middle value does not contradict the limit.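

No step can be read between compound 3 and compound 4, since each gives only a limit: the limit of > 20000 nM in this assay, at which 4 of the 4 values shown sit. The compounds shown leave open how strongly any of them inhibits, and whether 1-methylethenyl in place of 1-methylprop-1-en-1-yl changes anything.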